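Ethyl to tert-butyl on the fused core: intrinsic activity

A few compounds are considered here, and "the series" means these few. Any claim that something is new, unique, unknown or untested is made for them only; others in the source may bear on it.

Compound 1 `CC(=O)N1CCN(CCN2CCC(CNC(=O)c3cccc4[nH]c(C(C)C)nc34)CC2)CC1` reaches 76% in a functional assay for agonist activity at 5-hydroxytryptamine receptor 4 (Homo sapiens), read by cAMP accumulation; on this read-out lower numbers stand for smaller maximal responses and higher numbers for larger maximal responses. Compound 2 `CCc1nc2c(C(=O)NCC3CCN(CC(O)CN4CCN(S(C)(=O)=O)CC4)CC3)cccc2[nH]1` gives 22% in this assay, the lowest of the two numbers, with compound 1 standing higher by a margin beyond the scatter. Compound 3 `CC(C)(C)c1nc2c(C(=O)NCC3CCN(CC(O)CN4CCN(S(C)(=O)=O)CC4)CC3)cccc2[nH]1` differs from compound 2 only by tert-butyl in place of ethyl on an aromatic carbon. Among the compounds with values here, no single-point step between measured compounds is available to calibrate this change, so a small step upward in this assay, within or just beyond the scatter, is expected for the move a number 13 percentage points higher from compound 2 to compound 3 (beyond the scatter). Compound 3 is estimated at 35%, with a range from 12% to 60%.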

Compound 3, intrinsic activity: the largest response reached, in percent of the reference agonist's: 94%
Compound 3: middle estimate off by 59 percentage points, on the low side; measured number above the stated range.
By their numbers in this assay, from the lowest: compound 2; then compound 1; then compound 3.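

In this assay, the aromatic carbon between two ring nitrogen atoms proves to be a sensitive place in this series: tert-butyl in place of ethyl gives a number 72 percentage points higher from compound 2 to compound 3 (beyond the scatter) with the rest of the structure unchanged. A change of two added carbon atoms at this one place is therefore enough to move the maximal response substantially. The data at hand offer no explanation for this step.

Two groups at this place cannot define a trend with size or branching. Cyclopropyl or a straight butyl chain here would test whether the gain depends on the branched shape of tert-butyl.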